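Pyrazoline bromophenols: extra bromo on the phenol ring

The source may report more compounds than this note shows. Statements on the series, on what has been measured and on what is new or still open speak of the compounds shown alone.

Measured so far:
compound 1 `CCC(=O)N1N=C(C)CC1c1cc(Br)ccc1O`: 50300 nM
compound 2 `CC1=NN(C(=O)c2ccc(C)cc2)C(c2cc(Br)ccc2O)C1`: 21000 nM

Among the compounds with values here, in a functional assay on MGC-803 cells (Homo sapiens) for cytotoxicity, read by MTT assay, with a stated time of 48 h (on this read-out higher numbers stand for weaker inhibition and lower numbers for stronger inhibition), compound 1 gives the higher of the two numbers; the one step known, a 2.4-fold lower number from compound 1 to compound 2 (0.38 log units; beyond the scatter), concerns the group on the carbonyl carbon and does not reach the phenol ring. Compound 3 `CCC(=O)N1N=C(C)CC1c1cc(Br)cc(Br)c1O` differs from compound 1 only there: bromo in place of hydrogen on an aromatic carbon. Within the data shown here, no measured step bears on this change, so no shift beyond the scatter is expected, and the step of a 1.1-fold lower number from compound 1 to compound 3 (0.05 log units; within the scatter) is set near zero as an estimate. Compound 3 is therefore expected at about 45000 nM, within 15000 nM to 130000 nM.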

Compound 3, half-maximal inhibitory concentration: 38600 nM
Compound 3: the middle estimate sits 1.2-fold (0.07 log units) above what was measured, within the range that was stated.
By their numbers in this assay, from the lowest: compounds 2, 3 and 1 (each within the scatter of the next, the first and the last beyond it).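

In this assay, within the data shown here, the step of a 1.3-fold lower number from compound 1 to compound 3 (0.11 log units; within the scatter) gives the first reading on the phenol ring. A bromo group in place of hydrogen, ortho to a hydroxy group and meta to a bromo group, causes no shift beyond the scatter, at least with the ethyl group on the carbonyl carbon of compound 1. No measurement available here explains this result.

As far as these compounds go, whether the same holds with the 4-methylphenyl group of compound 2 remains open. Also open, from the compounds shown here alone, is whether a methoxy group, an amine or a carboxylic acid at this position would move the number.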